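A Pyrrole in Place of Hydroxyphenyl: Expected Growth Inhibition

A few compounds are considered here, and "the series" means these few. Any claim that something is new, unique, unknown or untested is made for them only; others in the source may bear on it.

Three compounds have been measured in a functional assay on U-251 cells (Homo sapiens) for inhibition, read by sulforhodamine B assay, with a stated time of 48 h; a higher number here means a weaker inhibitor of growth, a lower number a stronger inhibitor of growth:

Compound 1 `CC1=CC[C@H](C(C)(C)NC(=S)N/N=C/c2ccccc2O)CC1` gives 6400 nM.
Compound 2 `CC1=CC[C@H](C(C)(C)NC(=S)N/N=C/c2ccccc2[N+](=O)[O-])CC1` gives 20200 nM.
Compound 3 `CC1=CC[C@H](C(C)(C)NC(=S)N/N=C/c2cccc([N+](=O)[O-])c2)CC1` reaches only the assay limit, > 100000 nM.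

Compound 1 holds the lowest of the two real numbers, with compound 2 above it and compound 3 at the limit (the limit of > 100000 nM in this assay, at which 1 of the 3 values shown sits). Compound 4 `CC1=CC[C@H](C(C)(C)NC(=S)N/N=C/c2ccc[nH]2)CC1` differs from compound 1 by 1H-pyrrol-2-yl in place of 2-hydroxyphenyl on a carbon with a double bond to nitrogen. Within the data shown here, only one measured step touches this position: it removes the hydroxy group and is a 3.2-fold higher number from compound 1 to compound 2 (0.50 log units; beyond the scatter). The pyrrole change also removes the hydroxy group and its acceptor, so a step toward a higher number of roughly that size is expected, a 2.3-fold higher number from compound 1 to compound 4 (0.37 log units; beyond the scatter). Compound 4 is therefore estimated at about 15000 nM, with a likely range from 4000 nM to 60000 nM.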

Compound 4, concentration for 50% growth inhibition: 80 nM
For compound 4 the middle estimate is 190-fold (2.27 log units) above the measured one, outside the stated range (below it).
By their numbers in this assay, from the lowest: compound 4; then compound 1; then compound 2. At a limit, above all of these: compound 3.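

Changing the group on this carbon with a double bond to nitrogen can do far more than the earlier nitro-for-hydroxy step showed: in this assay, 1H-pyrrol-2-yl in place of 2-hydroxyphenyl gives an 80-fold lower number from compound 1 to compound 4 (1.90 log units; beyond the scatter). The entering group keeps a hydrogen-bond donor but has no hydrogen-bond acceptor, so an acceptor in this group is not needed for strong growth inhibition. Nothing measured here accounts for the size of this step.

On these data alone, it remains open whether the ring nitrogen's hydrogen matters. Furan-2-yl or 1-methylpyrrol-2-yl at this position could test that.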